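A few compounds are considered here, and "the series" means these few. Any claim that something is new, unique, unknown or untested is made for them only; others in the source may bear on it.

Measured so far in a functional assay on HeLa cells (Homo sapiens) for cytotoxicity, read by MTT assay, with a stated time of 48 h (on this read-out lower numbers stand for stronger inhibition and higher numbers for weaker inhibition), as follows:
- compound 1 `COc1cc(COCc2cn(Cc3cc(C)cnc3Cl)nn2)cc(OC)c1OC` gives 264000 nM
- compound 2 `COc1cc(C2=NOC(COCc3cn(Cc4cc(-c5ccccc5)cnc4Cl)nn3)C2)cc(OC)c1OC` gives 7300 nM

Compound 1 holds the higher of these two numbers, and the gap down to compound 2 lies beyond the scatter. Compound 3 `COc1cc(COCc2cn(Cc3cc(-c4ccccc4)cnc3Cl)nn2)cc(OC)c1OC` is still unmeasured. Relative to compound 1 it has phenyl in place of methyl on an aromatic carbon, para to a chloro group (phenyl in place of methyl on an aromatic carbon) and is otherwise the same.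

Among the compounds with values here, no measured pair isolates this change. Compound 2 gives 7300 nM and also carries a phenyl, but it is not a one-place neighbour of compound 1, so it offers only a hint of direction. A lower number in this assay is expected for compound 3, beyond the scatter but short of the full gap seen with compound 2. The estimated step is a 6.6-fold lower number from compound 1 to compound 3 (0.82 log units; beyond the scatter) in the direction of stronger inhibition. Compound 3 is estimated at 40000 nM with an expected range from 12000 nM to 130000 nM on this read-out.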

Compound 3, half-maximal inhibitory concentration: 41900 nM
Compound 3: middle estimate off by 1.0-fold (0.02 log units), on the low side, and the stated range covers the measured number.
By their numbers in this assay, from the lowest: compound 2; then compound 3; then compound 1.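

In this assay, the aromatic carbon para to a chloro group and two atoms from the ring nitrogen now has a direct one-place reading: phenyl in place of methyl gives a 6.3-fold lower number from compound 1 to compound 3 (0.80 log units; beyond the scatter). The position therefore accepts a group of 6 heavy atoms in place of 1 heavy atom, and the number falls rather than rises, so the larger group is not penalised in this cytotoxicity read-out. Neither group carries a hydrogen-bond donor, a hydrogen-bond acceptor or a net charge, so the change adds only carbon and one six-membered aromatic ring, and nothing measured on these compounds accounts for the shift.

With a single pair at this position, the effect of the aromatic ring cannot be separated from that of the added carbon count; a cyclohexyl group or a longer alkyl chain here would address that, while an amine or a carboxylic acid would test whether the position accepts anything other than carbon. On these data alone, it also remains open whether a pyridyl or a substituted phenyl would take the number lower than phenyl does.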